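The source may report more compounds than this note shows. Statements on the series, on what has been measured and on what is new or still open speak of the compounds shown alone.

Measured compounds:
- compound 1 `Cc1ccc(C2=Nn3c(Cc4ccc(S(C)(=O)=O)cc4)nnc3SC2)cc1`: 37.9% in a functional assay on HT-29 cells (Homo sapiens) for cytotoxicity, read by MTT assay, with a stated time of 48 h, tested at 50 uM; a higher number here means a stronger effect of the compound at the concentration tested, a lower number a weaker effect
- compound 2 `CS(=O)(=O)c1ccc(Cc2nnc3n2N=C(c2cc(Cl)sc2S(N)(=O)=O)CS3)cc1`: 27.5%
- compound 3 `CS(=O)(=O)c1ccc(Cc2nnc3n2N=C(c2cc4ccccc4c(=O)o2)CS3)cc1`: 14.9%

Compound 2 holds the second highest of these three numbers. Compound 1 sits above it, a change of a number 10.4 percentage points lower from compound 1 to compound 2 (beyond the scatter), and compound 3 sits below it, a gap that is also beyond the scatter. The step from compound 1 to compound 2 is the only one that touches the same position as the step now considered.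

Compound 4 `CS(=O)(=O)c1ccc(Cc2nnc3n2N=C(c2ccc(O)c(C(N)=O)c2)CS3)cc1` is not yet measured. It differs from compound 2 in one place: 3-carbamoyl-4-hydroxyphenyl in place of 5-chloro-2-sulfamoylthiophen-3-yl on a carbon with a double bond to nitrogen. The new group is a carbon-only six-membered aromatic ring carrying a hydroxy and a carbamoyl group, which makes compound 4 resemble compound 1 more than compound 2 does in that position. Among the compounds with values here, because the step from compound 1 to compound 2 was a number 10.4 percentage points lower from compound 1 to compound 2 (beyond the scatter), the reverse direction is expected here: a modest rise in this assay, though the hydroxy and carbamoyl groups have no counterpart among the measured compounds, so the size is uncertain. For compound 4 the expected value is 33% (range 18% to 48%). The expected step from compound 2 is a number 5.5 percentage points higher from compound 2 to compound 4 (within the scatter).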

Compound 4, a percentage reported as activity, at one concentration (the size of the read-out at that concentration, not a potency): 33.1%
The estimate for compound 4 lay 0.1 percentage points below the measured number; the range from low to high includes it.
By their numbers in this assay, from the lowest: compound 3; then compounds 2, 4 and 1 (each within the scatter of the next, the first and the last beyond it).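

In this assay, replacing 5-chloro-2-sulfamoylthiophen-3-yl with 3-carbamoyl-4-hydroxyphenyl gives a number 5.6 percentage points higher from compound 2 to compound 4 (within the scatter), and replacing 4-methylphenyl with the same group gives a number 4.8 percentage points lower from compound 1 to compound 4 (within the scatter). Compound 4 therefore cannot be told apart from either neighbour, even though the step between those two neighbours lies beyond the scatter, so this position accepts a carbon-only six-membered aromatic ring carrying hydroxy and carbamoyl groups with no readable difference from either earlier group. No data shown here explain this result.

The compounds shown leave open what the hydroxy and carbamoyl groups do when each stands alone on the ring. They also leave open whether a carboxylic acid or an amine in place of the carbamoyl group would give a reading beyond the scatter.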